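Ethyl in place of hydrogen on two fused cores

The source may report more compounds than this note shows. Statements on the series, on what has been measured and on what is new or still open speak of the compounds shown alone.

Measured compounds:
Compound 1 `C=CCn1ncc2c(CC)ncn2c1=O` in a functional assay for inhibition, with Homo sapiens as the target (on this read-out lower numbers stand for stronger inhibition and higher numbers for weaker inhibition), gives only a limit of the assay, > 48000 nM.
Compound 2 `Cc1ncn2c(Nc3cc[nH]n3)nccc12` in this assay gives 57000 nM.
Compound 3 `C=CCn1ncc2cncn2c1=O` in this assay gives only a limit of the assay, > 48000 nM.

Going by the values given here, compound 2 holds the only number in this assay; the other two values are limits, as summarised in the limit of > 48000 nM in this assay, at which 2 of the 3 values shown sit. The change from compound 3 to compound 1 is ethyl in place of hydrogen on an aromatic carbon; its size is a step that the two limits leave unreadable from compound 3 to compound 1, the two limits leaving it unreadable.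

Compound 4 `CCc1nc(C)c2ccnc(Nc3cc[nH]n3)n12` is not yet measured. It differs from compound 2 by ethyl in place of hydrogen on an aromatic carbon. Among the compounds with values here, this is the same kind of change as the one from compound 3 to compound 1, not the same: in compound 4 the ethyl sits between two ring nitrogen atoms, two ring bonds from the ring atom that bears a methyl group, whereas in compound 1 it sits next to the ring nitrogen, two ring bonds from the ring nitrogen. How the core of compound 2 differs from the core of compound 3 is not broken down here.

Within the data shown here, the only anchor is compound 2 at 57000 nM, since the same kind of change on the other core gave no readable size, a step that the two limits leave unreadable from compound 3 to compound 1. In this assay the expected step is therefore small, a 1.1-fold higher number from compound 2 to compound 4 (0.02 log units; within the scatter), with wide uncertainty. Compound 4 is estimated at 60000 nM, within 25000 nM to 150000 nM.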

Compound 4, half-maximal inhibitory concentration: 13000 nM
For compound 4 the middle estimate is 4.6-fold (0.66 log units) above the measured one; the whole stated range lies above it.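

In this assay, ethyl in place of hydrogen on an aromatic carbon gives a 4.4-fold lower number from compound 2 to compound 4 (0.64 log units; beyond the scatter), so on the core of compound 2 this change has a readable size. The same kind of change from compound 3 to compound 1 cannot be read, because both of its values are limits of the assay: the limit of > 48000 nM in this assay, at which 2 of the 4 values shown sit. The series therefore holds a single readable pair for this change, which does not show whether the step carries from one core to the other, nor how much depends on the place of the ethyl, which in compound 4 sits between two ring nitrogen atoms.

The compounds shown leave open whether a longer chain such as propyl, or an amine, on this same aromatic carbon of the core of compound 2 would shift the number further than ethyl or reverse the step. They also leave open whether any group on the core of compound 3 would bring its value within the readable range of the assay, which a comparison of the two cores would need.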